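This account rests on a few compounds, and the source may have more. Where it says the series, first, only, none or still open, it means among the compounds named here.

In a functional assay on HeLa cells (Homo sapiens) for antiproliferative activity, read by MTT assay, with a stated time of 48 h (a lower number here means a stronger inhibitor, a higher number a weaker inhibitor), compound 3 `COc1ccc2c(/C=C(\C)C(=O)c3cc(OC)c(OC)c([Se]C)c3)c[nH]c2c1` gives 21 nM. Compound 1 `COc1ccc2c(/C=C(\C)C(=O)c3cc(OC)c(OC)c([Se]C)c3)cn(C)c2c1`, which carries a methyl on the aromatic nitrogen, gives 32 nM. Compound 2 `COc1cc(C(=O)/C=C/c2c[nH]c3ccccc23)cc([N+](=O)[O-])c1OC` stands well apart from both at 1350 nM.

The next compound, compound 4 `COc1cc(C(=O)/C(C)=C/c2c[nH]c3ccccc23)cc([Se]C)c1OC`, departs from compound 3 in one place: hydrogen in place of methoxy on an aromatic carbon. This puts hydrogen in place of methoxy on an aromatic carbon.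

Going by the values given here, no measured step isolates this change. Among the compounds with values here, the only single-place step, a 1.5-fold lower number from compound 1 to compound 3 (0.18 log units; within the scatter), lies within the scatter, but it concerns the aromatic nitrogen and not this methoxy, so it offers no direct guide. Compound 2 also lacks the methoxy, and its 1350 nM hints that a compound without it may give a higher number. That hint is weak, since compound 2 differs from compound 3 in other places as well. A moderate rise is therefore expected rather than a collapse of activity, though a change within the scatter cannot be ruled out.

The estimate is a 3.8-fold higher number from compound 3 to compound 4 (0.58 log units; beyond the scatter), an expected move towards a higher number. For compound 4 the expected value is 80 nM, with an estimated range of 20 nM to 350 nM.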

Compound 4, half-maximal inhibitory concentration: 34 nM
Beside the measured number, compound 4's estimate is 2.4-fold (0.37 log units) above it; low and high end bracket the measured number.
By their numbers in this assay, from the lowest: compounds 3, 1 and 4 (each within the scatter of the next); then compound 2.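

In this assay, putting hydrogen in place of the methoxy on the six-membered aromatic ring of carbon only, part of the fused system, gives a 1.6-fold higher number from compound 3 to compound 4 (0.21 log units; within the scatter), so this methoxy is not needed to keep the number in the range of compound 3. With a 1.5-fold lower number from compound 1 to compound 3 (0.18 log units; within the scatter), there are now two single-place steps on this ring system, one at the aromatic nitrogen and one at this aromatic carbon, and neither moves the number beyond the scatter. The data shown offer no measurement that would account for this tolerance.

As far as these compounds go, it remains open whether a larger or different group at this aromatic carbon, such as an ethoxy chain, a hydroxyl, an amine or a chlorine atom, would also stay within the scatter of compound 4. From the compounds shown here alone, it is equally open whether hydrogen in place of this methoxy would give a similar step with a methyl on the aromatic nitrogen, as in compound 1, since the two changes have so far been seen only one at a time.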